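The source may report more compounds than this note shows. Statements on the series, on what has been measured and on what is new or still open speak of the compounds shown alone.

For the measured compounds named here, compound 2, `O=C(N[C@H]1CCN(Cc2cccc(C(F)(F)F)c2)C1)c1ccc(-c2cccs2)cc1`, is the stronger of the two compounds measured so far in an assay on HEK298 cells for displacement of a labelled ligand from D(4) dopamine receptor (Homo sapiens); a higher number here means a weaker inhibitor, a lower number a stronger inhibitor. In this assay compound 2 gives 22 nM, whereas compound 1, `O=C(N[C@H]1CCN(Cc2ccc(OC(F)(F)F)cc2)C1)c1cccc(-c2cccs2)c1`, gives 52 nM; the gap between them lies beyond the usual scatter, but the two structures differ in more than one place, so no single change can be read from it.

The next compound, compound 3, `O=C(N[C@H]1CCN(Cc2ccc(F)cc2)C1)c1ccc(-c2cccs2)cc1`, has not yet been measured. It differs from compound 2 in one place: 4-fluorophenyl in place of 3-(trifluoromethyl)phenyl on a saturated chain carbon bound to an amine nitrogen in a ring. The group that enters is smaller by the count given, and it carries a single fluorine instead of a trifluoromethyl group.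

Going by the values given here, with no directly comparable pair among the measured compounds, the size of this step cannot be taken from the data. The expectation is that the step of a 1.5-fold lower number from compound 2 to compound 3 (0.17 log units; within the scatter) is small, at most around the edge of the scatter, and if anything toward a lower number. On that basis compound 3 is expected to give about 15 nM in this assay, with a range from 5 nM to 50 nM.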

Compound 3, inhibition constant: 5 nM
Compound 3: the middle estimate sits 3.0-fold (0.48 log units) above what was measured, within the range that was stated.
By their numbers in this assay, from the lowest: compound 3; then compound 2; then compound 1.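

For the compounds shown here, replacing 3-(trifluoromethyl)phenyl with 4-fluorophenyl on a saturated chain carbon bound to an amine nitrogen in a ring gives the first single-place step that can be read in this assay, a 4.4-fold lower number from compound 2 to compound 3 (0.64 log units; beyond the scatter), and this lies beyond the scatter. It shows that the number in this assay responds to what the aromatic ring at this position carries, and that going from 10 heavy atoms to 7 in this group is compatible with the lowest number of the three, that of compound 3. Nothing measured here accounts for the size or direction of this step.

The step changes both the substituent and where it sits on the ring, so the compounds shown cannot separate the two; 3-fluorophenyl, 4-(trifluoromethyl)phenyl and unsubstituted phenyl would each isolate part of it. Going by these compounds, it also remains open whether larger or different groups at this position, such as 4-chlorophenyl or 4-methoxyphenyl, follow the same direction, and whether the change would have a similar effect on the core of compound 1.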